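Trading a urea for a plain benzamide

The source may report more compounds than this note shows. Statements on the series, on what has been measured and on what is new or still open speak of the compounds shown alone.

Measured so far:
Compound 1, `COc1cc(-c2nn(-c3cccc(NC(=O)c4cccc(C(F)(F)F)c4)c3)cc2-c2ccncc2)ccc1Cl`: 1660 nM
Compound 2, `COc1cc(-c2nn(-c3cccc(NC(=O)Nc4cccc(C(F)(F)F)c4)c3)cc2-c2ccncc2)ccc1Cl`: 570 nM

Both compounds were tested in a functional assay on KM12 cells (Homo sapiens) for inhibition, read by sulforhodamine B assay, with a stated time of 48 h; a higher number here means a weaker inhibitor, a lower number a stronger inhibitor. Among the compounds with values here, compound 2 stands at the lower of the two numbers, the stronger end, with the only other compound sitting higher: a 2.9-fold lower number from compound 1 to compound 2 (0.46 log units; beyond the scatter). Compound 3, `COc1cc(-c2nn(-c3cccc(NC(=O)c4ccccc4)c3)cc2-c2ccncc2)ccc1Cl`, has not yet been measured. It differs from compound 2 in one place: phenyl in place of (3-(trifluoromethyl)phenyl)amino on a carbonyl carbon. Within the data shown here, only one measured step bears on this, a 2.9-fold lower number from compound 1 to compound 2 (0.46 log units; beyond the scatter), and it covers just the exchange of the amide-type nitrogen link for a direct carbonyl-to-ring link; walking that step back would point toward a higher number. Among the measured compounds shown here, the loss of the trifluoromethyl group has no counterpart among the measured compounds, so its contribution is unknown. Compound 3 is therefore expected to give a higher number, estimated at 2500 nM with a range of 800 nM to 8000 nM in this assay. The expected step is a 4.4-fold higher number from compound 2 to compound 3 (0.64 log units; beyond the scatter).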

Compound 3, half-maximal inhibitory concentration: 560 nM
The estimate for compound 3 lay 4.5-fold (0.65 log units) above the measured number; the whole stated range lies above it.
By their numbers in this assay, from the lowest: compounds 3 and 2 (each within the scatter of the next); then compound 1.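

In this assay, the earlier pair showed only what the link on the carbonyl carbon does while the trifluoromethyl stayed in place; this result shows that the trifluoromethyl can matter on its own. On the benzamide, hydrogen in its place gives a clear gain (a 3.0-fold lower number from compound 1 to compound 3 (0.47 log units; beyond the scatter)), so the weaker number of compound 1 does not follow from the benzamide link alone. The position also accepts plain phenyl in place of the whole (3-(trifluoromethyl)phenyl)amino group with no change beyond the scatter (a 1.0-fold lower number from compound 2 to compound 3 (0.01 log units; within the scatter)), and no measurement on hand explains either step.

The compounds shown leave open whether the urea would keep its number without the trifluoromethyl. They also leave open how an amine or a carboxylic acid on the phenyl ring would move the number.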